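The source may report more compounds than this note shows. Statements on the series, on what has been measured and on what is new or still open speak of the compounds shown alone.

Measured compounds:
compound 1 `COc1ccc(NC(=O)NCCNS(=O)(=O)c2sccc2-c2ccc(C)cc2Oc2ccc(O)c(O)c2)cc1` — in an ADME assay on HEK-293T cells (Homo sapiens) for cytotoxicity, read by CCK-8 assay, with a stated time of 48 h (a higher number here means a weaker inhibitor, a lower number a stronger inhibitor), compound 1 gives a limit, > 20000 nM.
compound 2 `COc1ccc(NC(=S)NCCNS(=O)(=O)c2sccc2-c2ccc(C)cc2Oc2ccc(O)c(O)c2)cc1` — compound 2 likewise gives a limit, > 20000 nM.
compound 3 `Cc1ccc(-c2ccsc2S(=O)(=O)NCCNC(=O)Nc2cc(Cl)cc(Cl)c2)c(Oc2ccc(O)c(O)c2)c1` — compound 3 gives 6700 nM.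

Among the measured compounds shown here, compound 3 is thus the only compound with a number in this assay; the other two sit at the limit of > 20000 nM in this assay, at which 2 of the 3 values shown sit. Compound 4 `Cc1ccc(-c2ccsc2S(=O)(=O)NCCNC(=S)Nc2cccc([N+](=O)[O-])c2)c(Oc2ccc(O)c(O)c2)c1` differs from compound 3 by a group of 12 heavy atoms (7 carbon, 2 nitrogen, 2 oxygen, 1 sulfur; one six-membered aromatic ring of carbon only) in place of a group of 11 heavy atoms (7 carbon, 1 nitrogen, 1 oxygen, 2 chlorine; one six-membered aromatic ring of carbon only), on an amine nitrogen. The steps touching compound 3 are an at least 2.9-fold lower number from compound 1 to compound 3 (0.47 log units; beyond the scatter) and an at least 2.9-fold lower number from compound 2 to compound 3 (0.47 log units; beyond the scatter), each readable only as a lower bound. The step that the two limits leave unreadable from compound 1 to compound 2 gives no size. For the measured compounds named here, no measured step with a readable number brings in the nitro group or the thiocarbonyl. The step of a 1.8-fold higher number from compound 3 to compound 4 (0.25 log units; within the scatter) is expected to run upward, back toward the limit. Compound 4 is estimated at 12000 nM, within 3500 nM to 40000 nM.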

Compound 4, half-maximal inhibitory concentration: 7900 nM
The estimate for compound 4 lay 1.5-fold (0.18 log units) above the measured number, within the range that was stated.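

In this assay, among the compounds shown here, 3-nitrophenyl in place of 4-methoxyphenyl on the thiocarbonyl side gives a first step with one readable end (an at least 2.5-fold lower number from compound 2 to compound 4 (0.40 log units; beyond the scatter)), and the wider replacement on the amine nitrogen gives a similar bound (an at least 2.5-fold lower number from compound 1 to compound 4 (0.40 log units; beyond the scatter)). The group carrying 3-nitrophenyl and the thiocarbonyl cannot be told apart from (3,5-dichlorophenyl)carbamoyl (a 1.2-fold higher number from compound 3 to compound 4 (0.07 log units; within the scatter)). Compound 1 and compound 2 remain limits, not numbers: the limit of > 20000 nM in this assay, at which 2 of the 4 values shown sit.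

Still open, on these data alone, is how carbonyl and thiocarbonyl compare with one aryl group held fixed. Also open, as far as these compounds go, is how an aminophenyl or carboxyphenyl group would read here.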